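From methyl to ethoxy on the shared core

A few compounds are considered here, and "the series" means these few. Any claim that something is new, unique, unknown or untested is made for them only; others in the source may bear on it.

In a functional assay on MDA-MB-231 cells (Homo sapiens) for inhibition, read by MTT assay, with a stated time of 72 h (on this read-out higher numbers stand for weaker inhibition and lower numbers for stronger inhibition), compound 1 `Cc1ccccc1-c1cc(C(=O)N2CCC3(CC2)CC(=O)c2nn(C(C)(C)C)cc2O3)c2ccccc2n1` is reported as the limit > 10000 nM and not as a number.

Compound 2 `CN1CCN(c2cc(C(=O)N3CCC4(CC3)CC(=O)c3nn(C(C)(C)C)cc3O4)c3ccccc3n2)CC1` gives 8130 nM in this assay and compound 3 `Cc1cc(C(=O)N2CCC3(CC2)CC(=O)c2nn(C(C)(C)C)cc2O3)c2ccccc2n1` gives 4860 nM there. For the measured compounds named here, these two are the only numbers so far, and the gap between them is a 1.7-fold lower number from compound 2 to compound 3 (0.22 log units; within the scatter) so compound 3 cannot be separated from compound 2. Only an at least 2.0-fold lower number from compound 1 to compound 3 (0.31 log units; beyond the scatter) clears the scatter, whereas the floor of an at least 1.2-fold lower number from compound 1 to compound 2 (0.08 log units; that floor lies within the scatter) does not.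

Compound 4 `CCOc1cc(C(=O)N2CCC3(CC2)CC(=O)c2nn(C(C)(C)C)cc2O3)c2ccccc2n1` carries ethoxy in place of methyl on an aromatic carbon next to the ring nitrogen ethoxy in place of methyl on an aromatic carbon with the rest of the structure unchanged. Going by the values given here, all three measured steps exchange the group on this same carbon, but no measured compound carries ethoxy there.

The closest guide is compound 3, whose exchange with compound 2 gave only a 1.7-fold lower number from compound 2 to compound 3 (0.22 log units; within the scatter) even though the two groups differ widely. The expected result is a 1.0-fold higher number from compound 3 to compound 4 (0.01 log units; within the scatter) and so no step beyond the scatter is anticipated in either direction.

For compound 4 the estimated value in this assay is 5000 nM with an expected range from 1700 nM to 12000 nM in this assay.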

Compound 4, half-maximal inhibitory concentration: > 10000 nM
Compound 4 was reported as a limit (the forecaster's own chance of this, stated with the estimate: 15%); middle value at least 2.0-fold (0.30 log units) away from the limit.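

In this assay, ethoxy in place of methyl on the aromatic carbon next to the ring nitrogen gives an at least 2.0-fold higher number from compound 3 to compound 4 (0.31 log units; beyond the scatter), so this position is not indifferent to a small change without a ring, as the gap between compound 2 and compound 3 alone might have suggested. The size of the entering group does not order the series: against compound 2, which carries the larger 4-methylpiperazin-1-yl, the result is an at least 1.2-fold higher number from compound 2 to compound 4 (0.08 log units; that floor lies within the scatter), so compound 4 is not separated from compound 2 on this floor. Compound 4, like compound 1, is reported as a limit and not as a number, so the step between those two cannot be read and the full size of the weakening from methyl stays hidden: the limit of > 10000 nM in this assay, at which 2 of the 4 values shown sit.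

Open, from the compounds shown here alone, is whether the weaker result follows the oxygen attached to the aromatic carbon or the extra chain length, which methoxy and a plain ethyl group on the same carbon would begin to separate. Also open, going by these compounds, is how a small amine such as dimethylamino would compare there with the 4-methylpiperazin-1-yl of compound 2.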